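The compounds below may be only part of what the source reports. "The series", "measured", "known", "first", "only" and "open" are said of these compounds alone.

Compound 3 `COc1cc2c(Oc3ccc(NC(=O)c4cc(-c5ccccc5F)ccn4)cc3F)ccnc2cc1OCCCN1CCN(C)CC1` gives 220 nM in a functional assay on HT-29 cells (Homo sapiens) for cytotoxicity, read by MTT assay, with a stated time of 72 h (on this read-out higher numbers stand for weaker inhibition and lower numbers for stronger inhibition), which is the second highest of the three numbers shown. Compound 2 `COc1cc2c(Oc3ccc(NC(=O)c4cc(-c5ccc(C(F)(F)F)cc5)ccn4)cc3F)ccnc2cc1OCCCN1CCCCC1` gives 230 nM, within the scatter of compound 3, while compound 1 `COc1cc2c(Oc3ccc(NC(=O)c4cc(-c5ccccc5)ccn4)cc3F)ccnc2cc1OCCCN1CCN(C)CC1` gives 82 nM, and the step of a 2.7-fold higher number from compound 1 to compound 3 (0.43 log units; beyond the scatter) is the only one that separates two of these compounds. Compound 4 `COc1cc2c(Oc3ccc(NC(=O)c4cc(-c5ccc(C(F)(F)F)cc5)ccn4)cc3F)ccnc2cc1OCCCN1CCN(C)CC1` carries 4-(trifluoromethyl)phenyl in place of 2-fluorophenyl on an aromatic carbon, on an aromatic carbon of a six-membered aromatic ring with one nitrogen, meta to a large group and opposite the ring nitrogen. Within the data shown here, no measured step covers this exchange directly; compound 2, which bears the same 4-(trifluoromethyl)phenyl group on a different chain end, gives 230 nM. Compound 4 is therefore expected to show a 1.1-fold lower number from compound 3 to compound 4 (0.04 log units; within the scatter). Compound 4 is estimated at 200 nM, within 80 nM to 500 nM.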

Compound 4, half-maximal inhibitory concentration: 200 nM
The estimate for compound 4 equals the measured number at the digits printed; the range from low to high includes it.
By their numbers in this assay, from the lowest: compound 1; then compounds 4, 3 and 2 (each within the scatter of the next).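

In this assay, 4-(trifluoromethyl)phenyl in place of 2-fluorophenyl at this position gives a 1.1-fold lower number from compound 3 to compound 4 (0.04 log units; within the scatter), so these two substituted phenyl groups cannot be told apart here. Trifluoromethyl in place of hydrogen on the phenyl gives a 2.4-fold higher number from compound 1 to compound 4 (0.39 log units; beyond the scatter), which shows that a second substituent also moves the number beyond the scatter in the same direction as fluoro did. At the other end of the molecule, 4-methylpiperazin-1-yl in place of piperidin-1-yl gives a 1.2-fold lower number from compound 2 to compound 4 (0.06 log units; within the scatter). No measurement shown here explains these steps. On these data alone, whether a methoxy group or a nitrile on the phenyl would behave likewise remains open.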